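Adding a 3,4-dichlorophenyl to the shared core

A few compounds are considered here, and "the series" means these few. Any claim that something is new, unique, unknown or untested is made for them only; others in the source may bear on it.

Compound 1 `CCOC(=O)c1cc2ccc(OCCCn3cc(CNC(=O)CCCCC4CCSS4)nn3)cc2oc1=O` gives 32.4% in a functional assay on PC-12 cells (Rattus norvegicus) for cytotoxicity, read by MTT assay, with stated times of 3 h and 2 h, tested at 5 uM; a lower number here means a weaker effect, a higher number a stronger effect of the compound at the concentration tested. Compound 2 `COc1ccc(-c2cc3ccc(OCCCn4cc(CNC(=O)CCCCC5CCSS5)nn4)cc3oc2=O)cc1` gives 52.8%. Compound 3 `O=C(CCCCC1CCSS1)NCc1cn(CCCCOc2ccc3ccc(=O)oc3c2)nn1` gives 52.8%.

Compound 3 stands level with compound 2 at the digits shown, and the two together hold the highest of the three numbers; compound 1 lies lower, as the step of a number 20.4 percentage points higher from compound 1 to compound 2 (beyond the scatter) shows.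

Compound 4 `O=C(CCCCC1CCSS1)NCc1cn(CCCCOc2ccc3cc(-c4ccc(Cl)c(Cl)c4)c(=O)oc3c2)nn1` differs from compound 3 in one place: 3,4-dichlorophenyl in place of hydrogen on an aromatic carbon. The new group sits on an aromatic carbon of the six-membered ring with one oxygen, within the fused two-ring core.

Among the measured compounds shown here, only one measured step touches this position, a number 20.4 percentage points higher from compound 1 to compound 2 (beyond the scatter), where a 4-methoxyphenyl replaced an ethoxycarbonyl. That is not the same exchange as a ring entering in place of a hydrogen, and compound 2, which carries such a ring, is level with compound 3, which does not. A ring at this place therefore seems to go with a number no lower than that of compound 3, and the step of a number 3.2 percentage points higher from compound 3 to compound 4 (within the scatter) is expected to be small or within the scatter. Compound 4 is estimated at 56%, within 41% to 71%.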

Compound 4, a percentage reported as activity, at one concentration (the size of the read-out at that concentration, not a potency): 53.2%
Compound 4: middle estimate off by 2.8 percentage points, on the high side, within the range that was stated.
By their numbers in this assay, from the lowest: compound 1; then compounds 2, 3 and 4 (each within the scatter of the next).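

In this assay, placing 3,4-dichlorophenyl on this aromatic carbon gives a number 0.4 percentage points higher from compound 3 to compound 4 (within the scatter), so here a hydrogen gives way to a much larger ring group with no change that can be told from scatter. The earlier step at this position exchanged one group for another and did not show what a ring adds compared with hydrogen; this pair does, at least for this one ring on the core of compound 3. The data offer no measured reason why the read-out holds steady at this position.

Still open, as far as these compounds go, is whether a plain phenyl, without its two chlorines, or a phenyl carrying an amine or a carboxylic acid would also leave the number unchanged. A small group such as methyl on the same carbon also remains untested among the compounds shown.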